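Chloro for methyl on the fused ring of compound 3

This account rests on a few compounds, and the source may have more. Where it says the series, first, only, none or still open, it means among the compounds named here.

Three amides on a shared core have been run in an assay on CHO cells for displacement of a labelled ligand from adenosine receptor A3 (Homo sapiens), read by scintillation counting, with a stated time of 60 min; a higher number here means a weaker inhibitor, a lower number a stronger inhibitor. Compound 1 `O=C(CCCc1ccccc1)Nc1nc2ccccc2c(=O)s1` carries an unsubstituted fused ring; in this assay compound 1 reaches only the limit > 1000 nM. Compound 2 `COc1cccc(C#CC(=O)Nc2nc3ccccc3c(=O)s2)c1` has an alkyne linker in the amide side chain; in this assay compound 2 likewise stops at the limit > 1000 nM. Within the data shown here, compound 3 `Cc1ccc2nc(NC(=O)CCCc3ccccc3)sc(=O)c2c1` is the one member with a number: in this assay compound 3 gives 147 nM. Among the measured compounds shown here, that is the only number in the set; the other two values are limits, as the limit of > 1000 nM in this assay, at which 2 of the 3 values shown sit, records. For the measured compounds named here, the single step between measured compounds is an at least 6.8-fold lower number from compound 1 to compound 3 (0.83 log units; beyond the scatter), where the change is methyl in place of hydrogen on an aromatic carbon.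

Compound 4 `O=C(CCCc1ccccc1)Nc1nc2ccc(Cl)cc2c(=O)s1` is not yet measured. The change from compound 3 is chloro in place of methyl on an aromatic carbon. Going by the values given here, no measured step exchanges one substituent for another at this position; the step from compound 1 to compound 3 shows only that a methyl there beats a hydrogen, so it bears on compound 4 indirectly. With one substituent swapped for another of similar size, the step of a 1.0-fold higher number from compound 3 to compound 4 (0.01 log units; within the scatter) is expected to lie within the scatter, in no firm direction. Compound 4 is therefore estimated at 150 nM, with a range of 50 nM to 500 nM.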

Compound 4, inhibition constant: > 1000 nM
Compound 4 was reported as a limit; the forecaster's own chance of this, stated with the estimate: 10%; at least 6.6-fold (0.82 log units) between middle value and limit.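

In this assay, chloro in place of methyl on this aromatic carbon gives an at least 6.8-fold higher number from compound 3 to compound 4 (0.83 log units; beyond the scatter), although each group counts a single heavy atom and neither adds a hydrogen-bond donor or acceptor. The earlier compounds shown here showed only that methyl at this place gives a lower number than hydrogen; the new step shows that the identity of the substituent matters here, and that the lower number seen with methyl does not carry over to chloro in this pair. The step from compound 1 to compound 4 cannot be read, as both values are limits, so no statement can be made about chloro relative to hydrogen at this place.

Among these compounds, compound 3 remains the only member with a number, which leaves no second measured substituent on this carbon to set beside methyl: the limit of > 1000 nM in this assay, at which 3 of the 4 values shown sit. Whether an ethyl group, a methoxy group or a fluorine at this place would also give a measurable number stays open, as does whether methyl would have a comparable effect with the alkyne side chain of compound 2.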